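A few compounds are considered here, and "the series" means these few. Any claim that something is new, unique, unknown or untested is made for them only; others in the source may bear on it.

Three compounds sharing one core were tested in an ADME assay on J774 cells (Mus musculus, strain BALB/c) for cytotoxicity, read by resazurin assay, with a stated time of 72 h; a lower number here means that less compound is tolerated, a higher number that more compound is tolerated. Compound 1 `CC(/C=N/Nc1ccc([N+](=O)[O-])cc1)=N\NC(=O)c1ccccc1O` gives 29500 nM in this assay. Compound 2 `CC(/C=N/Nc1ccc([N+](=O)[O-])cc1)=N\NC(=O)c1ccc(N)cc1` gives 75000 nM. Compound 3 `CC(/C=N/Nc1ccc([N+](=O)[O-])cc1)=N\NC(=O)c1ccccc1F` reaches only the limit of this assay, > 100000 nM, so for compound 3 no number is known, only that limit. Each change of the group on the carbonyl carbon has so far moved the number upward: a 2.5-fold higher number from compound 1 to compound 2 (0.41 log units; beyond the scatter), and an at least 3.3-fold higher number from compound 1 to compound 3 (0.53 log units; beyond the scatter), whereas an at least 1.3-fold higher number from compound 2 to compound 3 (0.12 log units; that floor lies within the scatter). Compound 4 `COc1cc(C(=O)N/N=C(C)/C=N/Nc2ccc([N+](=O)[O-])cc2)ccc1O` carries 4-hydroxy-3-methoxyphenyl in place of 2-fluorophenyl on a carbonyl carbon. Compound 1, whose group on the carbonyl carbon also bears a hydroxy, gives 29500 nM, the lowest number seen. A lower number is therefore expected for compound 4, by an at least 1.8-fold lower number from compound 3 to compound 4 (0.25 log units; that floor lies within the scatter). Compound 4 is estimated at 55000 nM, within 20000 nM to 150000 nM.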

Compound 4, half-maximal cytotoxic concentration: > 100000 nM
Compound 4: a limit, no number (the forecaster's own chance of this, stated with the estimate: 35%); middle value at least 1.8-fold (0.25 log units) from the limit.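

A hydroxy on the group at this carbonyl carbon does not by itself bring the number down. In this assay compound 4 gives > 100000 nM, which is a limit and not a number; the comparison with the other hydroxy-bearing group shows an at least 3.3-fold higher number from compound 1 to compound 4 (0.53 log units; beyond the scatter), and the comparison with 4-aminophenyl shows only an at least 1.3-fold higher number from compound 2 to compound 4 (0.12 log units; that floor lies within the scatter). The step from 2-fluorophenyl cannot be read because both of its compounds sit at the limit: the limit of > 100000 nM in this assay, at which 2 of the 4 values shown sit.

Going by these compounds, how far compound 3 and compound 4 lie beyond that limit stays open. So does the effect of a carboxylic acid or a longer alkyl chain on this carbonyl carbon.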